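The source may hold more compounds than are shown below. What is called first, only, known or untested is meant among the compounds shown, and "the series" means these compounds.

Compound 1 `CC(C)c1ccc(-c2nc(SCc3cn(CC(=O)NC(=O)Nc4ccccn4)nn3)nc(Nc3ccc(F)cc3)c2C#N)cc1` gives, in a functional assay on ECa-109 cells (Homo sapiens) for inhibition, read by MTT assay, with a stated time of 72 h (on this read-out lower numbers stand for stronger inhibition and higher numbers for weaker inhibition), only a limit, > 64000 nM, and not a number (the limit of > 64000 nM in this assay, at which 1 of the 2 values shown sits). Compound 2 `COc1ccc(Nc2nc(SCc3cn(CC(=O)NC(=O)Nc4ccccn4)nn3)nc(-c3ccc(C(C)C)cc3)c2C#N)cc1` carries methoxy in place of fluoro on an aromatic carbon, and in this assay compound 2 gives 5420 nM. That step, an at least 11-fold lower number from compound 1 to compound 2 (1.07 log units; beyond the scatter), is the only measured one bearing on the present case. Compound 3 `COc1ccccc1Nc1nc(SCc2cn(CC(=O)NC(=O)Nc3ccccn3)nn2)nc(-c2ccc(C(C)C)cc2)c1C#N` differs from compound 1 by 2-methoxyphenyl in place of 4-fluorophenyl on a nitrogen on an aromatic ring. Since the measured step brought methoxy in place of fluoro while compound 3 brings 2-methoxyphenyl in place of 4-fluorophenyl, a downward step, though a smaller one, is expected for compound 3: an at least 4.2-fold lower number from compound 1 to compound 3 (0.63 log units; beyond the scatter). The estimate for compound 3 is 15000 nM, from 4000 nM to 64000 nM.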

Compound 3, half-maximal inhibitory concentration: 8960 nM
Estimate against measurement, compound 3: 1.7-fold (0.22 log units) above; measured number inside the range.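

In this assay, a second methoxyphenyl group on a nitrogen on an aromatic ring also improves on 4-fluorophenyl, with an at least 7.1-fold lower number from compound 1 to compound 3 (0.85 log units; beyond the scatter). Setting 2-methoxyphenyl in place of 4-methoxyphenyl gives a 1.7-fold higher number from compound 2 to compound 3 (0.22 log units; within the scatter), so the two methoxyphenyl groups cannot be told apart here. Compound 1 gives only a limit, so the step from it has no fixed size: the limit of > 64000 nM in this assay, at which 1 of the 3 values shown sits.

Going by these compounds, whether a hydroxyl or a dimethylamino group in place of methoxy would serve as well stays open, as does the effect of a plain phenyl on that nitrogen.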